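The compounds below may be only part of what the source reports. "The series", "measured", "known", "first", "only" and "open" are said of these compounds alone.

Compound 1 `OCCOCn1cnc2c(Cl)cc(Cl)cc21` gives > 100000 nM in a functional assay on KB cells (Homo sapiens) for inhibition; a lower number here means a stronger inhibitor, a higher number a weaker inhibitor.
Compound 2 `OCCOCn1cnc2c(Cl)c(Cl)ccc21` gives > 100000 nM in this assay.
Compound 3 `OCCOCn1c(S)nc2c(Cl)cc(Cl)cc21` gives > 100000 nM in this assay.

Each of these three readings is a limit of the assay and not a number. For compound 1 the reading is a limit. For compound 2 the reading is a limit. For compound 3 the reading is a limit. Together they sit at the limit of > 100000 nM in this assay, at which 3 of the 3 values shown sit, so none of the three is told apart from the others in this assay.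

Compound 3 differs from compound 1 in one place: sulfanyl in place of hydrogen on an aromatic carbon. Both readings are limits. This change gave a step that the two limits leave unreadable from compound 1 to compound 3; nothing can be said about whether the sulfanyl group helped or hurt. Compound 2 has the same atoms as compound 1, joined differently, and the difference between the two cores is not broken down here.

Compound 4 `OCCOCn1c(S)nc2c(Cl)c(Cl)ccc21` has not yet been measured in this assay. It differs from compound 2 by sulfanyl in place of hydrogen on an aromatic carbon, which is the same change as that from compound 1 to compound 3, at the same place on the ring system.

Among the measured compounds shown here, because the only comparable step is a step that the two limits leave unreadable from compound 1 to compound 3 and all three readings share (the limit of > 100000 nM in this assay, at which 3 of the 3 values shown sit), compound 4 is expected to remain at the limit, with an expected step that the limit leaves unreadable from compound 2 to compound 4. The estimate for compound 4 in this assay is 150000 nM, most likely reported as a limit, with a range from 30000 nM to 1000000 nM.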

Compound 4, half-maximal inhibitory concentration: > 100000 nM
Compound 4 was reported as a limit (the forecaster's own chance of this, stated with the estimate: 85%); the middle value lies beyond the limit too.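

Among the compounds shown here, compound 2 and compound 4 are both limits in this assay, so swapping hydrogen for sulfanyl gives no step that can be read between them. All four compounds share a single reading: the limit of > 100000 nM in this assay, at which 4 of the 4 values shown sit.

The compounds shown leave open how strongly any of the four inhibits, and whether the sulfanyl group helps or hurts on either core.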